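Isopropoxy in place of trifluoromethoxy: working notes

A few compounds are considered here, and "the series" means these few. Any claim that something is new, unique, unknown or untested is made for them only; others in the source may bear on it.

In a functional assay on K562 cells (Homo sapiens) for antiproliferative activity, read by MTT assay, with a stated time of 72 h (on this read-out lower numbers stand for stronger inhibition and higher numbers for weaker inhibition), compound 2 `COc1ccc(-c2ncnn2-c2cc(OC)c(OC)c(OC)c2)cc1` gives 950 nM. Compound 1 `COc1cc(-c2ncnn2-c2cccc(F)c2)cc(OC)c1OC` gives > 10000 nM, which is a limit and not a number. Compound 3 `COc1cc(-n2ncnc2-c2ccc(OC(F)(F)F)cc2)cc(OC)c1OC` gives > 10000 nM, also only a limit. The series thus shows (the limit of > 10000 nM in this assay, at which 2 of the 3 values shown sit).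

Compound 4 `COc1cc(-n2ncnc2-c2ccc(OC(C)C)cc2)cc(OC)c1OC` differs from compound 3 by isopropyl in place of trifluoromethyl on an oxygen on an aromatic ring, with isopropyl in place of trifluoromethyl on an oxygen on an aromatic ring. Among the measured compounds shown here, the one measured step on that oxygen is an at least 10-fold higher number from compound 2 to compound 3 (1.02 log units; beyond the scatter), which is large and beyond the scatter. A partial return towards compound 2 is therefore expected, to a lower number in this assay, although a limit remains possible. The expected step is an at least 2.5-fold lower number from compound 3 to compound 4 (0.39 log units; beyond the scatter). For compound 4 the estimated value is 4000 nM, with an expected range of 700 nM to 10000 nM.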

Compound 4, half-maximal inhibitory concentration: 800 nM
Beside the measured number, compound 4's estimate is 5.0-fold (0.70 log units) above it, and the stated range covers the measured number.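

At this oxygen on an aromatic ring, the loss seen with trifluoromethyl does not extend to isopropyl in this assay (an at least 12-fold lower number from compound 3 to compound 4 (1.09 log units; beyond the scatter)). Isopropyl and methyl at this place are not separated (a 1.2-fold lower number from compound 2 to compound 4 (0.07 log units; within the scatter)), so this assay does not distinguish the two groups here. Compound 3 gives (> 10000 nM), which is a limit, so the first step is only a bound: the limit of > 10000 nM in this assay, at which 2 of the 4 values shown sit.

The compounds shown leave open whether trifluoromethyl is alone in this loss. A longer chain such as n-butyl on this oxygen, or an amine in place of the oxygen, could still fall on either side.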